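This account rests on a few compounds, and the source may have more. Where it says the series, first, only, none or still open, it means among the compounds named here.

Compound 1 `Cc1ccc(N2CCN(c3ncnc4c3ncn4[C@@H]3O[C@H](CO)[C@@H](O)[C@H]3O)CC2)cc1` reads "not active" (no number reported) in a functional assay on HepG2 cells (Homo sapiens) for antiproliferative activity, read by sulforhodamine B assay, with a stated time of 72 h; on this read-out lower numbers stand for stronger inhibition and higher numbers for weaker inhibition
Compound 2 `CC(C)c1ccc(Nc2ncnc3c2ncn3[C@@H]2O[C@H](CO)[C@@H](O)[C@H]2O)cc1` reads 40000 nM in this assay

Within the data shown here, compound 2 holds the only number so far, and compound 1 has none. Compound 3 `OC[C@H]1O[C@@H](n2cnc3c(NCCC4=CCCCC4)ncnc32)[C@H](O)[C@@H]1O` is still unmeasured and carries 2-(cyclohex-1-en-1-yl)ethyl in place of 4-isopropylphenyl on a nitrogen on an aromatic ring on the shared core, that is, 2-(cyclohex-1-en-1-yl)ethyl in place of 4-isopropylphenyl on a nitrogen on an aromatic ring. Among the measured compounds shown here, no measured pair shows what such a change does, so the expectation rests on compound 2 at 40000 nM alone. In this assay the expected change is slightly downward and stays within the scatter, an estimated 1.6-fold lower number from compound 2 to compound 3 (0.20 log units; within the scatter) at most. Compound 3 is expected at 25000 nM with 8000 nM to 80000 nM as its estimated range.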

Compound 3, half-maximal inhibitory concentration: 1000 nM
Estimate against measurement, compound 3: 25-fold (1.40 log units) above, outside the stated range (below it).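

In this assay the change at this nitrogen on an aromatic ring gives a 40-fold lower number from compound 2 to compound 3 (1.60 log units; beyond the scatter) and so lies well beyond the scatter. The position therefore responds strongly to the group it carries, and a six-membered aromatic ring of carbon only is not needed there for a number as low as that of compound 3. Nothing available explains why this step is so large. From the compounds shown here alone, it remains open whether the double bond matters, since 2-cyclohexylethyl would test that directly. Going by these compounds, it is also open whether 2-phenylethyl, which keeps the chain but restores an aromatic ring, would read like compound 3 or like compound 2.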